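This account rests on a few compounds, and the source may have more. Where it says the series, first, only, none or still open, it means among the compounds named here.

Of the compounds shown here, three have been read in a functional assay on Caco-2 cells (Homo sapiens) for inhibition, read by MTT assay, with a stated time of 48 h, tested at 10 uM; a lower number here means less inhibition of growth, a higher number more inhibition of growth at the concentration tested. Compound 1 `Cc1cc(=O)c2c(O)cc(OC/C=C/c3ccccc3)c([C@H]3CCN(C)C[C@H]3O)c2o1` gives 9%, and compound 3 `Cc1cc(=O)c2c(O)c(CN3CCC(Cc4ccccc4)CC3)c(O)c([C@H]3CCN(C)C[C@H]3O)c2o1` gives 21%. Compound 2 `CCN(CC)Cc1c(O)c([C@H]2CCN(C)C[C@H]2O)c2oc(C)cc(=O)c2c1O`, at 17%, stands within the scatter of both. The unmeasured compound 4 `Cc1cc(=O)c2c(O)c(CN(C)CC(=O)O)c(O)c([C@H]3CCN(C)C[C@H]3O)c2o1` differs from compound 2 by (carboxymethyl)(methyl)amino in place of diethylamino on a saturated chain carbon bound to an aromatic carbon. For the measured compounds named here, no measured pair isolates this change. Compound 3 at 21% and compound 2 at 17% differ in their amine yet remain within the scatter, so no step beyond the scatter is expected in this assay. The expected step is a number 5 percentage points lower from compound 2 to compound 4 (within the scatter). For compound 4 the estimated value is 12%, with an expected range from 2% to 25%.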

Compound 4, percent growth inhibition at one concentration: 18%
Compound 4: the middle estimate sits 6 percentage points below what was measured, within the range that was stated.
By their numbers in this assay, from the lowest: compounds 1, 2, 4 and 3 (each within the scatter of the next, the first and the last beyond it).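

In this assay, for the compounds shown here, (carboxymethyl)(methyl)amino in place of diethylamino on a saturated chain carbon bound to an aromatic carbon gives a number 1 percentage points higher from compound 2 to compound 4 (within the scatter), the first step at this position that isolates a single change. At this one concentration, an amine carrying a carboxylic acid therefore reads the same as diethylamino within the scatter. Nothing shown here bears on why the number holds.

As far as these compounds go, whether an amide or methyl ester in place of the carboxylic acid, or a longer chain between the amine nitrogen and that acid, would read differently stays open. So does whether a morpholine on the same chain carbon would move the number beyond the scatter.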